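Aryl sulfonyl substituent exchange in the shared core

The compounds below may be only part of what the source reports. "The series", "measured", "known", "first", "only" and "open" are said of these compounds alone.

Compound 1 `O=C1C=CC(O)(c2cc3ccccc3n2S(=O)(=O)c2ccccc2)C=C1` and compound 2 `CCOC(=O)Nc1ccc(S(=O)(=O)n2c(C3(O)C=CC(=O)C=C3)cc3ccccc32)cc1` share one core and differ only on the sulfonyl-bearing ring; in a functional assay on A549 cells (Homo sapiens) for inhibition, read by MTT assay, with a stated time of 72 h (on this read-out lower numbers stand for stronger inhibition and higher numbers for weaker inhibition), compound 1 gives 500 nM and compound 2 gives 500 nM, level with each other, so compound 2 stands where compound 1 stands on these numbers. Compound 3 `COC(=O)CCc1ccc(S(=O)(=O)n2c(C3(O)C=CC(=O)C=C3)cc3ccccc32)cc1` differs from compound 2 by 2-(methoxycarbonyl)ethyl in place of (ethoxycarbonyl)amino on an aromatic carbon. Among the compounds with values here, the only measured step at this aromatic carbon, no change at the digits printed from compound 1 to compound 2 (within the scatter), lay within the scatter. On that basis compound 3 is expected to show no change at the digits printed from compound 2 to compound 3 (within the scatter). Compound 3 is estimated at 500 nM in this assay, within 250 nM to 1000 nM.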

Compound 3, half-maximal inhibitory concentration: 500 nM
Beside the measured number, compound 3's estimate shows no gap at the digits printed; the range from low to high includes it.
By their numbers in this assay, from the lowest: compounds 1, 2 and 3 (each within the scatter of the next).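

At this aromatic carbon, para to a large group, this assay shows no change at the digits printed from compound 2 to compound 3 (within the scatter) even though the hydrogen-bond donor of (ethoxycarbonyl)amino is lost and the nitrogen link gives way to carbon. Set against hydrogen, 2-(methoxycarbonyl)ethyl gives no change at the digits printed from compound 1 to compound 3 (within the scatter) so two different substituents of equal heavy-atom count now read level with the unsubstituted ring. As far as these compounds go, whether an amine, a carboxylic acid or a longer chain at this carbon would separate from these values remains open. No supporting data are available to account for the level readings.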